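Chain shortening and minimum effective dose in the electroshock series

The source may hold more compounds than are shown below. What is called first, only, known or untested is meant among the compounds shown, and "the series" means these compounds.

Measured so far:
compound 1, `CCCCCCCCCc1cccc(N2CCNCC2)n1`: 10 mg/kg in a functional assay on the whole organism with Mus musculus as the target, in the maximal electroshock model, with a stated time of 120 min; on this read-out lower numbers stand for an effect already at smaller amounts and higher numbers for an effect only at larger amounts of compound
compound 2, `CCCCCCc1cccc(N2CCNCC2)n1`: 10 mg/kg
compound 3, `CCCCCCCCc1cccc(N2CCNCC2)n1`: 10 mg/kg

All three measured compounds stand level in this assay: no change at the digits printed from compound 1 to compound 2 (within the scatter), no change at the digits printed from compound 1 to compound 3 (within the scatter), no change at the digits printed from compound 2 to compound 3 (within the scatter). Compound 4, `CCCCCc1cccc(N2CCNCC2)n1`, is not yet measured. It differs from compound 3 by hydrogen in place of propyl on a saturated chain carbon, five bonds along the chain from an aromatic carbon. The same change occurs once already, as hydrogen in place of propyl on a saturated chain carbon, six bonds along the chain from an aromatic carbon, where the step was no change at the digits printed from compound 1 to compound 2 (within the scatter). The two places are not identical: there the chain carbon lies six bonds along the chain from an aromatic carbon, here five bonds, so this is the same kind of change rather than the same one. The two cores differ by hydrogen in place of methyl on a saturated chain carbon, eight bonds along the chain from an aromatic carbon. Because the earlier step of no change at the digits printed from compound 1 to compound 2 (within the scatter) was flat, a flat step is expected here as well. The step for compound 4 is estimated as no change at the digits printed from compound 3 to compound 4 (within the scatter). Compound 4 is expected at 10 mg/kg, between 5 mg/kg and 20 mg/kg.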

Compound 4, minimum effective dose: 10 mg/kg
Compound 4: middle estimate and measured number agree at the digits printed; the range from low to high includes it.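

In this assay, hydrogen in place of propyl was read on two cores: the same change on two cores in this assay, no change at the digits printed (within the scatter) from compound 1 to compound 2 and no change at the digits printed (within the scatter) from compound 3 to compound 4, 1.0-fold (0.00 log units) apart, within the scatter of two such steps
Hydrogen in place of methyl was also read on two cores: the same change on two cores in this assay, no change at the digits printed (within the scatter) from compound 1 to compound 3 and no change at the digits printed (within the scatter) from compound 2 to compound 4, 1.0-fold (0.00 log units) apart, within the scatter of two such steps
The new steps read no change at the digits printed from compound 3 to compound 4 (within the scatter), no change at the digits printed from compound 2 to compound 4 (within the scatter) and no change at the digits printed from compound 1 to compound 4 (within the scatter), so these changes carry from core to core here only as flat steps, and this does not show how they would carry over where a step lies beyond the scatter.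

What the compounds shown leave open is whether this assay stays level with a methyl group, an ethyl chain or a decyl chain in place of the present chains. Also open, as far as these compounds go, is the reading with a carboxylic acid or an amine in their place.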